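The source may report more compounds than this note shows. Statements on the series, on what has been measured and on what is new or still open speak of the compounds shown alone.

In an ADME assay on the whole organism (Mus musculus, strain CD-1) for pharmacokinetics, read by LC-MS, with a stated time of 7 h, at a dose of 20 mg/kg by the oral route; on this read-out higher numbers stand for higher exposure at the dose given and lower numbers for lower exposure:

- Compound 1 `CC(Sc1nc2c(cnn2C)c(=O)n1-c1ccccc1)c1ccccn1`: 6320 ng.h/mL
- Compound 2 `CC(Sc1nc2nn(C3COC3)cc2c(=O)n1-c1ccccc1)c1ccccn1`: 2510 ng.h/mL

Compound 1 holds the higher of the two numbers, and compound 2 lies below it by more than the usual scatter. Compound 3 `CC(Sc1nc2c(cnn2C)c(=O)n1-c1ccccc1)c1ccccc1` keeps the core of compound 1, with phenyl in place of pyridin-2-yl on a saturated chain carbon bound to a saturated chain carbon and a sulfur. Within the data shown here, no measured pair shows this change, so only a small downward move in this assay is expected, none beyond the scatter. The estimated step is a 1.4-fold lower number from compound 1 to compound 3 (0.15 log units; within the scatter). Compound 3 is expected at 4500 ng.h/mL, within a range of 1600 ng.h/mL to 11000 ng.h/mL.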

Compound 3, area under the concentration-time curve: 1410 ng.h/mL
The estimate for compound 3 lay 3.2-fold (0.50 log units) above the measured number; measured number below the stated range.
By their numbers in this assay, from the lowest: compounds 3 and 2 (each within the scatter of the next); then compound 1.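

Swapping pyridin-2-yl for phenyl on a saturated chain carbon bound to a saturated chain carbon and a sulfur gives a 4.5-fold lower number from compound 1 to compound 3 (0.65 log units; beyond the scatter) in this assay, so this position is not indifferent to the change. Among these compounds, in this single pair, the higher exposure goes with the ring nitrogen of pyridin-2-yl, which the earlier compounds could not show. No measurement here accounts for the difference. The compounds shown leave open how pyridin-3-yl or a carboxylic acid would fare at this position. They also leave open whether the same change on the core of compound 2 would give a similar step.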